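The source may hold more compounds than are shown below. What is called first, only, known or untested is meant among the compounds shown, and "the series" means these compounds.

Compound 2 is `N#CC1=C(/N=C/Nc2ccccc2)N(c2ccccc2)C(=O)N2CCCCC(N3CCCC3)C12` and compound 1 is `N#CC1=C(NCN2CCCCC2)N(c2ccccc2)C(=O)N2CCCCC(N3CCCC3)C12`, the two sharing one core. In a functional assay on the whole organism (strain albino) for inhibition, with Rattus norvegicus as the target, read by paw edema, with stated times of 1 h and 3 h, at a dose of 20 mmol/kg by the intraperitoneal route (on this read-out higher numbers stand for a stronger effect at the one dose given and lower numbers for a weaker effect), compound 1 gives 42.1%, and compound 2 gives 79.3%, the higher of the two numbers; the change was a number 37.2 percentage points higher from compound 1 to compound 2 (beyond the scatter). Compound 3 is `N#CC1=C(NCC(=O)N2CCCCC2)N(c2ccccc2)C(=O)N2CCCCC(N3CCCC3)C12`, not yet measured. It differs from compound 2 in a single place: a group of 10 heavy atoms (7 carbon, 2 nitrogen, 1 oxygen; one six-membered non-aromatic ring with 1 hetero atom) in place of a group of 9 heavy atoms (7 carbon, 2 nitrogen; one six-membered aromatic ring of carbon only), on a double-bonded ring carbon. Among the measured compounds shown here, only one measured step bears on this change, a number 37.2 percentage points higher from compound 1 to compound 2 (beyond the scatter), in which a group with one six-membered non-aromatic ring with 1 hetero atom gave way to a group with one six-membered aromatic ring of carbon only. The move to compound 3 runs the other way, bringing back a group with one six-membered non-aromatic ring with 1 hetero atom, though with the carbonyl added. The expectation is therefore a drop of a number 29.3 percentage points lower from compound 2 to compound 3 (beyond the scatter) in this assay, a step beyond the scatter though not necessarily as large as the one seen. Compound 3 is expected to give 50%, with the estimate ranging from 30% to 70%.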

Compound 3, a percentage reported as inhibition, in the whole organism at one dose (the size of the read-out at that dose, not a potency): 53.5%
Compound 3: the middle estimate sits 3.5 percentage points below what was measured, within the range that was stated.
By their numbers in this assay, from the lowest: compound 1; then compound 3; then compound 2.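

In this assay the carbonyl counts for something on its own: with (piperidin-1-yl)carbonyl in place of piperidin-1-yl on a saturated chain carbon bound to an amine nitrogen, the read-out shows a number 11.4 percentage points higher from compound 1 to compound 3 (beyond the scatter) and so recovers part of what the earlier step gained. That recovery is incomplete, since (((piperidin-1-yl)carbonyl)methyl)amino on the double-bonded ring carbon, in place of the group with the six-membered aromatic ring of carbon only, gives a number 25.8 percentage points lower from compound 2 to compound 3 (beyond the scatter) and leaves the aromatic group the highest of the three compounds at this position. Nothing available explains why these groups differ in this way.

The compounds shown leave open whether the piperidine ring itself matters beside the carbonyl, which morpholin-4-yl or a plain dimethylamino group in its place would test. They also leave open whether a longer chain between the carbonyl and the amine nitrogen, or a pyridine ring in place of the phenyl of the group in compound 2, would move the read-out at this one dose.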